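Aryl in place of alkyl on the five-membered ring

The source may report more compounds than this note shows. Statements on the series, on what has been measured and on what is new or still open speak of the compounds shown alone.

Three compounds of the series have numbers in a functional assay on MDA-MB-231 cells (Homo sapiens) for inhibition, read by MTT assay, with a stated time of 24 h, tested at 100 uM; on this read-out higher numbers stand for more inhibition at the one concentration tested (going by the name of the read-out) and lower numbers for less inhibition. Compound 1 `COc1ccc(/C=N/NC(=O)c2ccc(O[C@@H]3O[C@H](CO)[C@@H](O)[C@H](O)[C@H]3O)cc2)cc1` gives 11.3%, compound 2 `O=C(N/N=C/C1CCCCC1)c1ccc(O[C@@H]2O[C@H](CO)[C@@H](O)[C@H](O)[C@H]2O)cc1` gives 0.88%, and compound 3 `CCCCCc1nnc(-c2ccc(O[C@@H]3O[C@H](COC(C)=O)[C@@H](OC(C)=O)[C@H](OC(C)=O)[C@H]3OC(C)=O)cc2)o1` gives 21.5%, the highest of the three and beyond the scatter from both others. Among the measured compounds shown here, the single measured step, a number 10.4 percentage points lower from compound 1 to compound 2 (beyond the scatter), is the only comparison in which an aromatic group is exchanged for a non-aromatic one. Compound 4 `CC(=O)OC[C@H]1O[C@@H](Oc2ccc(-c3nnc(-c4ccc([N+](=O)[O-])cc4)o3)cc2)[C@H](OC(C)=O)[C@@H](OC(C)=O)[C@@H]1OC(C)=O` differs from compound 3 by 4-nitrophenyl in place of pentyl on an aromatic carbon. For the measured compounds named here, no measured step bears directly on this exchange at an aromatic carbon; read in the reverse sense, the measured step suggests a modest rise at most. The estimate for compound 4 is therefore 28%, within 12% to 45%, an expected step of a number 6.5 percentage points higher from compound 3 to compound 4 (within the scatter).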

Compound 4, a percentage reported as inhibition, at one concentration (the size of the read-out at that concentration, not a potency): 58%
For compound 4 the middle estimate is 30 percentage points below the measured one; measured number above the stated range.
By their numbers in this assay, from the lowest: compound 2; then compound 1; then compound 3; then compound 4.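

In this assay, the position on an aromatic carbon of the five-membered aromatic ring responds strongly to its substituent: 4-nitrophenyl in place of pentyl gives a number 36.5 percentage points higher from compound 3 to compound 4 (beyond the scatter), with the rest of the core unchanged. Among the compounds shown here, this is the first step read at this position, and it is larger than any step seen before. No measured evidence accounts for the rise.

The compounds shown do not separate the contribution of the aromatic ring from that of the nitro group. Plain phenyl or 4-aminophenyl at this position would separate them.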